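The compounds below may be only part of what the source reports. "The series", "measured", "known", "first", "only" and "open" are said of these compounds alone.

In a functional assay on DU-145 cells (Homo sapiens) for antiproliferative activity, read by luminescence, with a stated time of 96 h (a higher number here means a weaker inhibitor, a lower number a stronger inhibitor), compound 1 `COc1cc2c(cc1NS(=O)(=O)c1cc(Br)ccc1OC)OC(C)(C)C(=O)N2` gives 23200 nM and compound 2 `COc1ccc(Br)cc1S(=O)(=O)Nc1cc2c(cc1O)NC(=O)C(C)(C)O2` gives 33200 nM on the same shared core. Among the measured compounds shown here, compound 2 therefore stands level with its only measured neighbour, as the two values lie within the scatter of each other. The change to compound 3 `COc1ccc(Br)cc1S(=O)(=O)Nc1ccc2c(c1)OC(C)(C)C(=O)N2` is hydrogen in place of hydroxy on an aromatic carbon and amounts to hydrogen in place of hydroxy on an aromatic carbon, ortho to a large group. For the measured compounds named here, one measured step bears on this site: a 1.4-fold higher number from compound 1 to compound 2 (0.16 log units; within the scatter) for hydrogen in place of methyl on the same oxygen. That step keeps the oxygen, however, so the data hold no direct measure of losing it, and the comparison is only indirect. With that single small step as the guide, no step beyond the scatter is expected in this assay and the uncertainty stays wide. The expected step is a 1.7-fold lower number from compound 2 to compound 3 (0.22 log units; within the scatter) and it remains an estimate. For compound 3 the estimated value is 20000 nM with an expected range from 7000 nM to 50000 nM in these cells.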

Compound 3, half-maximal inhibitory concentration: 30900 nM
Estimate against measurement, compound 3: 1.5-fold (0.19 log units) below; low and high end bracket the measured number.
By their numbers in this assay, from the lowest: compounds 1, 3 and 2 (each within the scatter of the next).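

Hydrogen in place of hydroxy on this aromatic carbon, ortho to a large group, gives a 1.1-fold lower number from compound 2 to compound 3 (0.03 log units; within the scatter) in this assay, the first direct reading on losing the oxygen altogether, and that loss leaves no step beyond the scatter. Hydrogen in place of methoxy at the same place gives a 1.3-fold higher number from compound 1 to compound 3 (0.12 log units; within the scatter), so with the earlier step on the methyl, hydroxy, methoxy and hydrogen now form a closed set of three changes, none of which separates the three compounds from one another in these cells. The series thus reads as flat across these three groups at this position, and no measured evidence is available to account for that flat reading.

Going by these compounds, whether a group of another kind here, such as an amine, a carboxylic acid or a longer alkoxy chain, would give a step beyond the scatter stays open. The compounds shown differ only at this one place, so how far the rest of the shared core governs these numbers also stays open.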